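Trimming the Nitrogen Substituent from Isopropyl to Ethyl

The compounds below may be only part of what the source reports. "The series", "measured", "known", "first", "only" and "open" are said of these compounds alone.

Of the compounds shown here, three have been measured in an assay on membranes from Jurkat cells for displacement of a labelled ligand from Sigma intracellular receptor 2 (Homo sapiens), read by scintillation counting, with a stated time of 1 h; on this read-out lower numbers stand for stronger inhibition and higher numbers for weaker inhibition.

Compound 1, `Cn1nc(CN2CCCC2)nc1-c1ccc(C(C)(C)C)cc1`, gives > 1000 nM, which is a limit of the assay rather than a number.
Compound 2, `CC(C)(C)c1ccc(-c2nc(CN3CCCC3)nn2C2CC2)cc1`, gives 750 nM.
Compound 3, `CC(C)n1nc(CN2CCCC2)nc1-c1ccc(C(C)(C)C)cc1`, gives 1460 nM.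

Among the two actual numbers, compound 3 has the highest; its nearest neighbour is compound 2, and the step of a 1.9-fold higher number from compound 2 to compound 3 (0.29 log units; within the scatter) stays within the usual scatter, so the two cannot be told apart. Compound 4, `CCn1nc(CN2CCCC2)nc1-c1ccc(C(C)(C)C)cc1`, differs from compound 3 by hydrogen in place of methyl on a saturated chain carbon bound to an aromatic nitrogen and a saturated chain carbon; seen one bond further out, the isopropyl becomes an ethyl.

The steps already measured all change the same group on the aromatic nitrogen. From methyl to cyclopropyl, an at least 1.3-fold lower number from compound 1 to compound 2 (0.12 log units; that floor lies within the scatter). From methyl to isopropyl, a step that the limit leaves unreadable from compound 1 to compound 3, since compound 1 sits at the limit of > 1000 nM in this assay, at which 1 of the 3 values shown sits. The swap from cyclopropyl to isopropyl also stayed within the scatter. Every change here has moved the number little, and the ethyl of compound 4 sits between the methyl of compound 1 and the isopropyl of compound 3 in size.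

For compound 4 the step of a 1.2-fold lower number from compound 3 to compound 4 (0.09 log units; within the scatter) is therefore expected to fall within the scatter. Compound 4 is estimated at 1200 nM, with a range from 500 nM to 3000 nM.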

Compound 4, inhibition constant: 1710 nM
For compound 4 the middle estimate is 1.4-fold (0.15 log units) below the measured one, within the range that was stated.
By their numbers in this assay, from the lowest: compounds 2, 3 and 4 (each within the scatter of the next, the first and the last beyond it).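

Removing one methyl from the isopropyl gives a 1.2-fold higher number from compound 3 to compound 4 (0.07 log units; within the scatter), so in this assay ethyl and isopropyl on this nitrogen cannot be told apart, and the trimmed chain neither gains nor loses anything that can be read. Among the compounds shown here, the new compound also supplies the first readable step beyond the scatter at this position, a 2.3-fold higher number from compound 2 to compound 4 (0.36 log units; beyond the scatter), a modest step that sets the cyclopropyl of compound 2 apart from the ethyl, although compound 3, with its isopropyl, stays within the scatter of both and so blurs any clean split between the ring and the open chains. Compound 1 carries a limit rather than a number, and its step to compound 4 cannot be read, which means the methyl cannot yet be placed in this series: the limit of > 1000 nM in this assay, at which 1 of the 4 values shown sits.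

Going by these compounds, whether a propyl chain, a cyclobutyl ring or a hydroxyethyl chain on this nitrogen would go clearly further than the cyclopropyl of compound 2 stays open. The four compounds also share everything else in their structures, which leaves open whether a different amine in place of the one they carry would move the numbers more than this substituent has.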